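The source may hold more compounds than are shown below. What is called first, only, known or untested is meant among the compounds shown, and "the series" means these compounds.

Measured compounds:
Compound 1, `O=C(Nc1ncc(Cc2ccc(F)cc2)s1)C1CCCCC1`: in an ADME assay on HepG2 2.2.15 cells (Homo sapiens) for cytotoxicity (on this read-out higher numbers stand for lower toxicity in this test and lower numbers for higher toxicity in this test), compound 1 reaches only the limit > 50000 nM.
Compound 2, `O=C(Nc1ncc(Cc2ccc(F)cc2)s1)c1ccc(Br)cc1`: in this assay compound 2 likewise reaches only the limit > 50000 nM.
Compound 3, `O=C(Nc1ncc(Cc2ccc(Cl)cc2)s1)c1ccc(F)cc1F`: in this assay compound 3 is recorded as "not toxic" (no number reported), without any number attached.

All three compounds share the same core, and the only place where they differ is the group attached to the carbonyl carbon. For the measured compounds named here, the one measured step, a step that the two limits leave unreadable from compound 1 to compound 2, cannot be sized, because the limit of > 50000 nM in this assay, at which 2 of the 3 values shown sit, means both ends of the step sit at the edge of what the test could measure. Going by the values given here, compound 3 stands on no number at all; its two companions sit at a limit, so nothing among the measured values sets any compound apart from the others in this assay.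

Compound 4, `O=C(Nc1ncc(Cc2ccc(Cl)cc2)s1)c1cccs1`, differs from compound 3 by thiophen-2-yl in place of 2,4-difluorophenyl on a carbonyl carbon. Among the compounds with values here, no measured step speaks to this exchange directly, and the one step that does touch the carbonyl carbon, from compound 1 to compound 2, is unreadable. With every measured value pointing to absent toxicity, no shift beyond the scatter is expected in either direction. Compound 4 is therefore estimated to give about 50000 nM in this assay, within 20000 nM to 100000 nM, most probably reported once more as a limit rather than a number.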

Compound 4, half-maximal cytotoxic concentration: > 50000 nM
Compound 4: no number, only a limit (the forecaster's own chance of this, stated with the estimate: 80%); the middle value lies on the limit itself.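

Compound 4 gives only a limit in this assay, > 50000 nM. Compound 3 has no number at all, so no new step can be read between compound 3 and compound 4. The compounds shown leave open whether any group on the carbonyl carbon changes the toxicity in this assay, as none of them has a value that is a plain number.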